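Thiosemicarbazone Swap on a Terpene Scaffold: Cytotoxicity Outlook

A few compounds are considered here, and "the series" means these few. Any claim that something is new, unique, unknown or untested is made for them only; others in the source may bear on it.

Measured compounds, values from a functional assay on NCI-H460 cells (Homo sapiens) for cytotoxicity, read by sulforhodamine B assay; a higher number here means a weaker inhibitor of growth, a lower number a stronger inhibitor of growth:
Compound 1, `CC1=CC[C@@H]([C@@](C)(O)CCCC(C)(C)NC(=S)N/N=C\c2ccccc2Cl)CC1`: 24600 nM
Compound 2, `CC1=CC[C@@H]([C@@](C)(O)CCCC(C)(C)NC(=S)N/N=C\c2ccc(Cl)cc2)CC1`: 8720 nM

Compound 2 holds the lowest number of the two in this assay; its nearest neighbour, compound 1, differs by a 2.8-fold lower number from compound 1 to compound 2 (0.45 log units; beyond the scatter), a modest shift that rests only on moving the chlorine around the aromatic ring. Compound 3, `CC1=CC[C@@H]([C@@](C)(O)CCCC(C)(C)NC(=S)N/N=C(/C)c2ccccc2)CC1`, is not yet measured. It differs from compound 2 by a group of 9 heavy atoms (8 carbon, 1 nitrogen; one six-membered aromatic ring of carbon only) in place of a group of 9 heavy atoms (7 carbon, 1 nitrogen, 1 chlorine; one six-membered aromatic ring of carbon only), on an amide-type nitrogen. Going by the values given here, no measured pair removes the chlorine or adds a methyl on the carbon double-bonded to nitrogen, so the one step in hand bears on it only loosely: it shows that edits on this arm move the number modestly. A step of similar size, probably toward a higher number, is expected, and compound 3 is estimated at 16000 nM (range 5500 nM to 45000 nM), a change of a 1.8-fold higher number from compound 2 to compound 3 (0.26 log units; within the scatter) from compound 2.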

Compound 3, concentration for 50% growth inhibition: 12600 nM
Compound 3: middle estimate off by 1.3-fold (0.10 log units), on the high side; the measured number falls inside the stated range.
By their numbers in this assay, from the lowest: compounds 2, 3 and 1 (each within the scatter of the next, the first and the last beyond it).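

In this assay this change on an amide-type nitrogen, which brings in a methyl on the carbon double-bonded to nitrogen and an unsubstituted aromatic ring in place of the chlorinated ones, gives two steps within the scatter (a 1.4-fold higher number from compound 2 to compound 3 (0.16 log units; within the scatter); a 2.0-fold lower number from compound 1 to compound 3 (0.29 log units; within the scatter)). Compound 3 therefore cannot be separated from either chlorinated compound, even though those two stand apart from each other beyond the scatter, so chlorine is not needed for a number in this range among these three compounds. Nothing measured here accounts for this result.

The compounds shown leave open what the methyl and the loss of chlorine each contribute alone, since the two occur together in this change. They also leave open how a methoxy group or a nitrile on the aromatic ring would read.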